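Swapping the Chlorobenzyl Amide for a Propyl Amide

This account rests on a few compounds, and the source may have more. Where it says the series, first, only, none or still open, it means among the compounds named here.

Compound 1, `C=CC1=C(C(=O)NCc2ccc(Cl)cc2)C(c2ccc(OC)cc2)OC1`, in a functional assay on QGY7701 cells (Homo sapiens) for cytotoxicity, read by MTT assay, with a stated time of 24 h; on this read-out lower numbers stand for stronger inhibition and higher numbers for weaker inhibition: > 100000 nM, a limit of the assay.
Compound 2, `C=CC1=C(C(=O)NCc2ccccc2F)C(c2ccc(F)cc2)OC1`, in this assay: 51400 nM.
Compound 3, `C=CC1=C(C(=O)NCc2ccc(C)cc2)C(c2ccc(OC)c(OC)c2)OC1`, in this assay: 69100 nM.

Compound 1 stands at the limit of > 100000 nM in this assay, at which 1 of the 3 values shown sits, so for compound 1 only a limit is known and no number. Compound 2 gives a measured number in this assay, and compound 3 likewise gives a measured number, both in the weak range; the two lie within the usual scatter of each other, so nothing is said about their order. Within the data shown here, no step between two measured compounds is available, and the three values together show only that the shared core carries weak activity in this assay.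

Compound 4, `C=CC1=C(C(=O)NCCC)C(c2ccc(OC)cc2)OC1`, is not yet measured. It differs from compound 1 as ethyl in place of 4-chlorophenyl on a saturated chain carbon bound to an amide-type nitrogen. Since compound 1 sits at the limit, the step from compound 1 to compound 4 is expected to be none beyond the scatter, with a step that the limit leaves unreadable from compound 1 to compound 4. Compound 4 is therefore estimated at 120000 nM, with a range from 40000 nM to 400000 nM, and it is expected that this assay may again report only a limit rather than a number.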

Compound 4, half-maximal inhibitory concentration: > 100000 nM
Compound 4: a limit, no number (the forecaster's own chance of this, stated with the estimate: 60%); the middle value is on the limit's open side.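

No step can be read between compound 1 and compound 4 in this assay, because both values are limits of the assay and not numbers: the limit of > 100000 nM in this assay, at which 2 of the 4 values shown sit.

The compounds shown leave open whether the change from 4-chlorobenzyl to propyl on the shared core alters activity at all.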